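This account rests on a few compounds, and the source may have more. Where it says the series, first, only, none or still open, it means among the compounds named here.

In an assay on microsomes from liver for inhibition of acyl-CoA desaturase 1 (Rattus norvegicus) (on this read-out higher numbers stand for weaker inhibition and lower numbers for stronger inhibition), compound 1 `OCc1nnc(-c2ccc(N3CCC(Oc4ccccc4C(F)(F)F)CC3)nn2)s1` gives 3.2 nM, the lowest of the three numbers recorded so far. Compound 2 `FC(F)(F)c1cccc(OC2CCN(c3ccc(-n4ccnc4)nn3)CC2)c1` gives 19 nM in this assay, and compound 3 `CC(=O)c1ccccc1OC1CCN(c2ccc(-n3ccnc3)nn2)CC1` gives 34 nM; both gaps to compound 1 lie beyond the scatter, so compound 1 is the strongest inhibitor among the three measured compounds. Compound 4 `OCc1nnc(-c2ccc(N3CCC(Oc4ccccc4C(F)(F)F)CC3)nn2)o1` has not yet been measured. It differs from compound 1 in one place: 5-(hydroxymethyl)-1,3,4-oxadiazol-2-yl in place of 5-(hydroxymethyl)-1,3,4-thiadiazol-2-yl on an aromatic carbon. The ring keeps its size and its count of donors and acceptors, and the hydroxymethyl group is retained. Among the measured compounds shown here, no pair of measured compounds shows this exchange, so the size of the step cannot be read from the numbers in hand. The expectation is that the step of a 1.6-fold higher number from compound 1 to compound 4 (0.19 log units; within the scatter) is small, most likely a slight rise in the number that does not clearly exceed the scatter. Compound 4 is therefore estimated at 5 nM, with a range of 1.5 nM to 16 nM.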

Compound 4, half-maximal inhibitory concentration: 2.9 nM
For compound 4 the middle estimate is 1.7-fold (0.24 log units) above the measured one, within the range that was stated.
By their numbers in this assay, from the lowest: compounds 4 and 1 (each within the scatter of the next); then compounds 2 and 3 (each within the scatter of the next).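

In this assay, among the compounds shown here, 5-(hydroxymethyl)-1,3,4-oxadiazol-2-yl in place of 5-(hydroxymethyl)-1,3,4-thiadiazol-2-yl gives a 1.1-fold lower number from compound 1 to compound 4 (0.04 log units; within the scatter) and is the first exchange that can be read directly. At this aromatic carbon, para to a large group, the ring sulfur can therefore give way to oxygen with the hydroxymethyl group retained, and compound 1 and compound 4 cannot be told apart on this read-out. Nothing available gives a reason for this outcome.

What the hydroxymethyl group itself contributes stays open, since the compounds shown do not include a carboxylic acid or an aminomethyl group in its place on either ring. As far as these compounds go, it is also open whether a 1,2,4-triazole at this position would match the two rings compared here.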